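A few compounds are considered here, and "the series" means these few. Any claim that something is new, unique, unknown or untested is made for them only; others in the source may bear on it.

Of the compounds shown here, three built on a shared core have been tested in a functional assay on COLO 205 cells (Homo sapiens) for inhibition, read by sulforhodamine B assay; a lower number here means a stronger inhibitor of growth, a higher number a weaker inhibitor of growth. Compound 1, `c1ccc(-c2ccc(-c3ccc(-c4nc5ccccc5[nH]4)cc3)cc2)cc1`, gives 100000 nM in this assay, the highest of the three numbers. Compound 3, `COc1ccc(-c2ccc(-c3ccc(-c4nc5ccccc5[nH]4)cc3)cc2)cc1`, gives 45200 nM; it differs from compound 1 by a methoxy in place of hydrogen on an aromatic carbon, and the step of a 2.2-fold lower number from compound 1 to compound 3 (0.34 log units; beyond the scatter) is modest but beyond the scatter. Compound 2, `Cc1ccc2[nH]c(-c3ccc(-c4ccc(-c5ccc(N(C)C)cc5)cc4)cc3)nc2c1`, gives 9210 nM; it differs from compound 1 in two places, so its number shows only that a dimethylamino together with a methyl on the core goes with a considerably lower value than compound 1.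

Compound 4, `CN(C)c1ccc(-c2ccc(-c3ccc(-c4nc5ccccc5[nH]4)cc3)cc2)cc1`, has not yet been measured. Compared with compound 1 the change is dimethylamino in place of hydrogen on an aromatic carbon. The single-change step from compound 1 to compound 3 lowered the number modestly, and compound 2, which carries the same dimethylamino plus a further methyl, sits well below compound 1. Taken together these point to a clear drop for compound 4 in this assay, though how far is uncertain. Compound 4 is therefore expected to show a step of a 5.6-fold lower number from compound 1 to compound 4 (0.74 log units; beyond the scatter), with an estimated value of 18000 nM, between 7000 nM and 45000 nM.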

Compound 4, concentration for 50% growth inhibition: 100000 nM
Estimate against measurement, compound 4: 5.6-fold (0.74 log units) below; the whole stated range lies below it.
By their numbers in this assay, from the lowest: compound 2; then compound 3; then compounds 1 and 4 (each within the scatter of the next).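

In this assay, the step of no change at the digits printed from compound 1 to compound 4 (within the scatter) shows that dimethylamino in place of hydrogen, on an aromatic carbon para to a large group, does not by itself move the number. The two groups at this position are also not interchangeable: the step of a 2.2-fold higher number from compound 3 to compound 4 (0.34 log units; beyond the scatter) separates dimethylamino from methoxy, so of the two only methoxy goes with a lower number than hydrogen in this set. The low number of compound 2 now takes on a different meaning, since the step of an 11-fold higher number from compound 2 to compound 4 (1.04 log units; beyond the scatter) involves only the methyl on an aromatic carbon of the core, and that methyl, not the dimethylamino alone, is the change that goes with the large difference.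

No measurement on hand explains why these compounds differ. Going by these compounds, it remains open whether the methyl would lower the number with hydrogen or methoxy at the far end as well, and whether a primary amine, a hydroxyl or a carboxylic acid at this position would behave like methoxy or like dimethylamino.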